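A few compounds are considered here, and "the series" means these few. Any claim that something is new, unique, unknown or untested is made for them only; others in the source may bear on it.

Working notes on the series, starting from an ADME assay for acid dissociation. Among the compounds with values here, compound 1 (`O=[N+]([O-])c1ccc2c(c1)S(=O)(=O)NC(NC1CCC1)=N2`) gives 7.89, the lower of the two numbers so far. Compound 2 (`O=S1(=O)N=C(NC2CCC2)Nc2ccc(Cl)cc21`), which carries chloro, gives 9.36, a gap beyond the scatter.

Compound 3 (`O=S1(=O)NC(NC2CCC2)=Nc2ccc(F)cc21`) has not yet been measured in this assay. It differs from compound 1 by fluoro in place of nitro on an aromatic carbon. Within the data shown here, no measured pair differs in one place only, so the size of this change has no direct precedent. The expectation rests on compound 2, which also has no nitro and stands at 9.36. A rise beyond the scatter is expected, close in size to the gap between the two measured compounds: the estimated step is a number 1.41 log units higher from compound 1 to compound 3 (beyond the scatter). For compound 3 the expected value is 9.3, with an estimated range from 8.9 to 9.7.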

Compound 3, acid dissociation constant: 9.57
For compound 3 the middle estimate is 0.27 log units below the measured one; measured number inside the range.
By their numbers in this assay, from the lowest: compound 1; then compounds 2 and 3 (each within the scatter of the next).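

In this assay the series now has its first direct measure of a change at this aromatic carbon: fluoro in place of nitro gives a number 1.68 log units higher from compound 1 to compound 3 (beyond the scatter) as a large step. Compound 3, with fluoro, and compound 2, with chloro, stand within the scatter of each other, so among the three compounds only the nitro compound, compound 1, stands apart. Nothing measured on hand accounts for the size of this step.

From the compounds shown here alone, whether nitro is alone in standing apart remains open, since an amine, a methoxy group or a nitrile on this carbon could fall near either side of the gap. The compounds shown also leave open how any change elsewhere on the shared core would read in this assay, as all three differ only at this carbon.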